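Propylamino to (2-methoxyethyl)amino in a thiadiazole series

A few compounds are considered here, and "the series" means these few. Any claim that something is new, unique, unknown or untested is made for them only; others in the source may bear on it.

Within the data shown here, in an assay on isolated protein for inhibition of Amine oxidase [flavin-containing] A (Homo sapiens), read by fluorescence and Amplex Red, with a stated time of 30 min, tested at 1 mM (a lower number here means a weaker effect, a higher number a stronger effect of the compound at the concentration tested), compound 2 `CCCNc1nnc(SCC(=O)N(Cc2cccc([N+](=O)[O-])c2)c2ccc(F)cc2)s1` gives 95%, the higher of the two numbers so far, though its only neighbour, compound 1 `CCCCNc1nnc(SCC(=O)N(Cc2cccc([N+](=O)[O-])c2)c2ccc(F)cc2)s1` with 90.5%, lies within the scatter of it, as a number 4.5 percentage points higher from compound 1 to compound 2 (within the scatter) shows. The unmeasured compound 3 `COCCNc1nnc(SCC(=O)N(Cc2cccc([N+](=O)[O-])c2)c2ccc(F)cc2)s1` differs from compound 2 by methoxy in place of methyl on a saturated chain carbon, two bonds along the chain from a nitrogen on an aromatic ring. Among the measured compounds shown here, the one measured step, a number 4.5 percentage points higher from compound 1 to compound 2 (within the scatter), touches the same chain but cuts it one bond further out, exchanging hydrogen for methyl, and it moved the read-out by an amount inside the usual scatter. For the measured compounds named here, no measured pair shows the effect of an added methoxy on this chain, so the step from propylamino to (2-methoxyethyl)amino rests on analogy alone. Given that the chain end tolerated shortening without a shift beyond the scatter, compound 3 is expected to remain a strong inhibitor, with a step of a number 7 percentage points lower from compound 2 to compound 3 (within the scatter) that is estimated to lie within or only slightly beyond the scatter. The estimate for compound 3 in this assay is therefore 88%, expected between 65% and 98%.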

Compound 3, a percentage reported as inhibition, at one concentration (the size of the read-out at that concentration, not a potency): 94.1%
Beside the measured number, compound 3's estimate is 6.1 percentage points below it; low and high end bracket the measured number.
By their numbers in this assay, from the lowest: compounds 1, 3 and 2 (each within the scatter of the next).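

In this assay, methoxy in place of methyl on a saturated chain carbon, two bonds along the chain from a nitrogen on an aromatic ring, gives a number 0.9 percentage points lower from compound 2 to compound 3 (within the scatter). Among these compounds, this is the first measured change on this chain that brings in an oxygen and a hydrogen-bond acceptor, where the earlier step only exchanged hydrogen for methyl. The same place also accepts methoxy in place of ethyl, with a number 3.6 percentage points higher from compound 1 to compound 3 (within the scatter), so all three chain ends shown stay within the scatter of one another, and nothing available explains this insensitivity.

On these data alone, the read-out gives the size of the effect at one concentration and not a potency, so it remains open whether these three compounds would separate at lower concentrations. It also remains open whether this tolerance extends to a chain end carrying an amine or a carboxylic acid, or to a longer chain, since every end shown here is a short alkyl or methoxy group.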